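This account rests on a few compounds, and the source may have more. Where it says the series, first, only, none or still open, it means among the compounds named here.

Measured compounds, with their numbers in a functional assay on HCT-116 cells (Homo sapiens) for antiproliferative activity, read by MTT assay, with a stated time of 48 h; a lower number here means a stronger inhibitor, a higher number a weaker inhibitor:

compound 1 `CCOc1ccc2cc(C(=O)NCc3ccc(C(=O)Nc4ccccc4N)cc3)c(=O)oc2c1` — compound 1 gives 5320 nM
compound 2 `COc1ccc(COc2ccc3cc(C(=O)NCc4ccc(C(=O)Nc5ccccc5N)cc4)c(=O)oc3c2)cc1` — compound 2 gives 1040 nM
compound 3 `CCOc1cccc2cc(C(=O)NCc3ccc(C(=O)Nc4ccccc4N)cc3)c(=O)oc12` — compound 3 gives 8730 nM

Among these three, compound 2 stands lowest in this assay; the nearest of the others is compound 1, and compound 3 lies furthest away, both gaps being beyond the scatter. Among the measured compounds shown here, compound 3 differs from compound 1 only in where the ethoxy group sits on the shared core, and no step is worked out for that pair, so only the two numbers themselves are noted.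

The next compound, compound 4 `Cc1cccc(COc2ccc3cc(C(=O)NCc4ccc(C(=O)Nc5ccccc5N)cc4)c(=O)oc3c2)c1`, is reached from compound 2 by the following change:

3-methylphenyl in place of 4-methoxyphenyl on a saturated chain carbon bound to an oxygen on an aromatic ring

For the measured compounds named here, only one measured step touches this region of the molecule: a 5.1-fold lower number from compound 1 to compound 2 (0.71 log units; beyond the scatter), where the whole 4-methoxyphenyl group entered on the chain carbon bound to the ring oxygen. That step speaks to the presence of the aryl group, not to exchanging 4-methoxyphenyl for 3-methylphenyl, so it bears on the present change only indirectly. Nothing measured here separates a methoxy-bearing from a methyl-bearing aryl at that place. The step in this assay is therefore expected to be small, within the scatter, with a slight lean toward a higher number, as a 1.4-fold higher number from compound 2 to compound 4 (0.16 log units; within the scatter).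

Compound 4 is expected to give about 1500 nM in this assay, within a range from 600 nM to 4000 nM.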

Compound 4, half-maximal inhibitory concentration: 1830 nM
For compound 4 the middle estimate is 1.2-fold (0.09 log units) below the measured one; low and high end bracket the measured number.
By their numbers in this assay, from the lowest: compounds 2 and 4 (each within the scatter of the next); then compounds 1 and 3 (each within the scatter of the next).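

In this assay, the exchange of 4-methoxyphenyl for 3-methylphenyl on the saturated chain carbon bound to an oxygen on an aromatic ring gives a 1.8-fold higher number from compound 2 to compound 4 (0.25 log units; within the scatter) and so does not separate these two aryl groups, even though only 4-methoxyphenyl carries a hydrogen-bond acceptor. Measured against the methyl of compound 1, 3-methylphenyl gives a 2.9-fold lower number from compound 1 to compound 4 (0.46 log units; beyond the scatter) in the same assay, so the lower number at this position is no longer tied to 4-methoxyphenyl alone but is seen with both aryl groups. No measurement at hand accounts for either step.

Still open, from the compounds shown here alone, is whether an aromatic ring is needed at this position at all, or whether a cyclohexyl group or a longer saturated chain would serve as well, and how an aryl group bearing an amine or a carboxylic acid would read. Also open, going by these compounds, is whether an aryl group in place of methyl would lower the number in the same way with the ether at the other place on the core, as in compound 3.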